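Swapping a Carboxy End for a Two-Ring Group

A few compounds are considered here, and "the series" means these few. Any claim that something is new, unique, unknown or untested is made for them only; others in the source may bear on it.

Of the compounds shown here, two have been tested so far for their ability to stop the growth of cancer cells. In a functional assay on MDA-MB-231 cells (Homo sapiens) for antiproliferative activity, read by luminescence, with a stated time of 24 h (a lower number here means a stronger inhibitor, a higher number a weaker inhibitor), compound 1 `Cc1c(C)c2c(c(C)c1OC(=O)CCCC[C@@H]1SC[C@@H]3NC(=O)N[C@@H]31)CCC(C)(COc1ccc(CC3SC(=O)NC3=O)cc1)O2` gives a measured 6500 nM.

Compound 2 `Cc1c(C)c2c(c(C)c1OC(=O)CCC(=O)O)CCC(C)(COc1ccc(/C=C3\SC(=O)NC3=O)cc1)O2` reads > 25000 nM. Going by these compounds, that reading is a limit of the assay and not a number, so the true position of compound 2 remains unknown.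

Compound 3 `Cc1c(C)c2c(c(C)c1OC(=O)CCCC[C@@H]1SC[C@@H]3NC(=O)N[C@@H]31)CCC(C)(COc1ccc(/C=C3\SC(=O)NC3=O)cc1)O2` has not yet been measured. It is made from compound 2 by one structural change a group of 11 heavy atoms (7 carbon, 2 nitrogen, 1 oxygen, 1 sulfur; one five-membered non-aromatic ring with 1 hetero atom, one five-membered non-aromatic ring with 2 hetero atoms) in place of a group of 3 heavy atoms (1 carbon, 2 oxygen; no ring), on a saturated chain carbon, two bonds along the chain from a carbonyl carbon: the carboxy group leaves, and a group of 11 heavy atoms, with one five-membered non-aromatic ring with 1 hetero atom and one five-membered non-aromatic ring with 2 hetero atoms, enters on a saturated chain carbon, two bonds along the chain from a carbonyl carbon.

Going by the values given here, no measured pair shows what such a change does in this assay. Among the compounds with values here, the only firm number is that of compound 1 at 6500 nM, so a moderate gain in strength, beyond the scatter, is expected. The estimated step is an at least 2.7-fold lower number from compound 2 to compound 3 (0.44 log units; beyond the scatter), and it is uncertain since it starts from a limit. For compound 3 the expected value is 9000 nM, with an estimated range of 3000 nM to 25000 nM.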

Compound 3, half-maximal inhibitory concentration: 3500 nM
Compound 3: middle estimate off by 2.6-fold (0.41 log units), on the high side; low and high end bracket the measured number.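

In this assay, placing the group with two five-membered non-aromatic rings where the carboxy stood, on a saturated chain carbon two bonds along the chain from a carbonyl carbon, gives an at least 7.1-fold lower number from compound 2 to compound 3 (0.85 log units; beyond the scatter), the first sign that this position responds to a change. Compound 2 supplies a limit and not a number to that step, so its true size stays unknown: the limit of > 25000 nM in this assay, at which 1 of the 3 values shown sits.

The other comparison concerns a different place, an aromatic carbon, where one group replaces another; a 1.9-fold lower number from compound 1 to compound 3 (0.27 log units; within the scatter) shows that these two groups cannot be told apart in this assay.

With only two groups shown at the chain position, it remains open whether the gain needs both rings, or whether a simple amine, a methyl ester or a plain longer carbon chain would read the same. Going by these compounds, it also remains open how the one measured cell line relates to others, since all three compounds are compared on MDA-MB-231 cells alone and over a single stated time.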